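This account rests on a few compounds, and the source may have more. Where it says the series, first, only, none or still open, it means among the compounds named here.

The measured compounds:
compound 1, `Nc1cc(N)c2nc(-c3ccccc3)c(Oc3ccc(Cl)c(Cl)c3)nc2c1`, in a functional assay on ACHN cells (Homo sapiens) for inhibition, read by sulforhodamine B assay, with a stated time of 48 h (on this read-out higher numbers stand for lower toxicity in this test and lower numbers for higher toxicity in this test), gives < 100000 nM, which is a limit of the assay and not a number.
compound 2, `Nc1cc(N)c2nc(-c3ccccc3)c(NCc3ccc(F)cc3)nc2c1`, in this assay gives 5620 nM.

Compound 2 thus holds the only number shown in this assay; the one other value is a limit. Compound 3, `Nc1cc(N)c2nc(-c3ccccc3)c(Sc3ccc(Cl)c(Cl)c3)nc2c1`, has not yet been measured in this assay. It differs from compound 2 in one place: (3,4-dichlorophenyl)sulfanyl in place of (4-fluorobenzyl)amino on an aromatic carbon. Within the data shown here, the single measured step, a step that the limit leaves unreadable from compound 1 to compound 2, cannot be read because the limit of < 100000 nM in this assay, at which 1 of the 2 values shown sits, hides its size, so no measured step tells how large a change between a (4-fluorobenzyl)amino group and a 3,4-dichlorophenyl-bearing group is, or in which direction it runs. The step from compound 2 to compound 3 is therefore expected to be modest, with wide uncertainty. Compound 3 is estimated at 8000 nM, in a range from 2000 nM to 40000 nM. The expected step is a 1.4-fold higher number from compound 2 to compound 3 (0.15 log units; within the scatter), within the scatter of this kind of measurement. It remains possible that compound 3 returns only a limit.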

Compound 3, concentration lethal to 50% of the cells: 5620 nM
Compound 3: the middle estimate sits 1.4-fold (0.15 log units) above what was measured; the range from low to high includes it.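

At the aromatic carbon ortho to a phenyl group, this assay now gives its first readable step: no change at the digits printed from compound 2 to compound 3 (within the scatter). This exchange takes out (4-fluorobenzyl)amino, with 1 hydrogen-bond donor, and puts in (3,4-dichlorophenyl)sulfanyl, with 0 hydrogen-bond donors, and for this one pair the read-out shows no difference beyond the scatter. The steps that involve compound 1, including the one from the 3,4-dichlorophenoxy group to the (3,4-dichlorophenyl)sulfanyl group, cannot be read, because compound 1 holds a limit and not a number: the limit of < 100000 nM in this assay, at which 1 of the 3 values shown sits.

Compound 2 and compound 3 differ in both the linking atoms and the aromatic substituents, and the compounds shown do not separate these two parts of the change, which a (3,4-dichlorophenyl)amino group or a (4-fluorobenzyl)sulfanyl group at this position could begin to do. Also open, from the compounds shown here alone, is whether the flat result at this position extends to groups of a different kind, such as a carboxylic acid, a morpholine or a longer alkyl chain, since a single pair of compounds cannot show how widely the position tolerates change.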